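The source may hold more compounds than are shown below. What is called first, only, known or untested is meant among the compounds shown, and "the series" means these compounds.

Measured in an ADME assay on HEK293 cells (Homo sapiens) for cytotoxicity, read by resazurin assay, with a stated time of 48 h; on this read-out lower numbers stand for higher toxicity in this test and higher numbers for lower toxicity in this test:
- compound 1 `Cc1ccccc1S(=O)(=O)Nc1ccc(-c2nc3ccccc3o2)cc1`: > 100000 nM
- compound 2 `COc1cccc(S(=O)(=O)Nc2ccc3oc(-c4ccccc4)nc3c2)c1`: 63000 nM
- compound 3 `O=S(=O)(Nc1ccc2oc(-c3ccccc3)nc2c1)c1cccc(F)c1`: 68000 nM

Compound 1 carries on its sulfonyl sulfur a 2-methylphenyl group. In this assay compound 1 returns only a limit, > 100000 nM, not a number; this is the limit of > 100000 nM in this assay, at which 1 of the 3 values shown sits. Compound 1 therefore stands at the top edge of what the assay reports, and its true position above that edge is not known.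

Compounds 2 and 3 share a different core from compound 1 and differ only in a substituent on an aromatic carbon; their values lie within the scatter of each other, a 1.1-fold higher number from compound 2 to compound 3 (0.03 log units; within the scatter). Going by the values given here, that is the only measured step in the set, and it concerns fluoro in place of methoxy on an aromatic carbon, not the sulfonyl-borne aryl group, so it bears on the change to compound 4 only as a general sign that small aryl substituent changes here have not moved this read-out.

Compound 4 `O=S(=O)(Nc1ccc(-c2nc3ccccc3o2)cc1)c1ccc(Cl)c(Cl)c1` differs from compound 1 in this way: 3,4-dichlorophenyl in place of 2-methylphenyl on a sulfonyl sulfur. Among the compounds with values here, no measured step covers a change at this place. The expectation is for no step beyond the scatter, with compound 4 staying at or near the limit: the expected step is an at least 1.1-fold lower number from compound 1 to compound 4 (0.04 log units; that floor lies within the scatter). For compound 4 the estimate in this assay is 90000 nM, with a range from 35000 nM to 250000 nM.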

Compound 4, half-maximal cytotoxic concentration: > 100000 nM
Compound 4 gave a limit, no number; the forecaster's own chance of this, stated with the estimate: 50%; middle value at least 1.1-fold (0.04 log units) away from the limit.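

In this assay compound 4 gives > 100000 nM, a limit and not a number. Compound 1 also gives a limit, > 100000 nM, so no step can be read between compound 1 and compound 4: the limit of > 100000 nM in this assay, at which 2 of the 4 values shown sit.

Still open, from the compounds shown here alone, is whether 3,4-dichlorophenyl in place of 2-methylphenyl on a sulfonyl sulfur changes this read-out at all.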